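Swapping the anilino substituent on a fused quinone core

The source may hold more compounds than are shown below. What is called first, only, known or untested is meant among the compounds shown, and "the series" means these compounds.

Measured so far in a functional assay on ECa-109 cells for inhibition, with ECa-109 cell line (Homo sapiens) as the target, read by sulforhodamine B assay; on this read-out higher numbers stand for weaker inhibition and lower numbers for stronger inhibition:
- compound 1, `O=C1C=C(Nc2ccc(C(F)(F)F)cc2)C(=O)c2c1nc1n2[C@H]2OC[C@@H](O)[C@H]2OC1`, gives 5500 nM
- compound 2, `O=C1C(N2CCCC2)=CC(=O)c2c1nc1n2[C@H]2OC[C@@H](O)[C@H]2OC1`, gives > 16000 nM
- compound 3, `O=C1C(Nc2ccc(C(F)(F)F)cc2)=CC(=O)c2c1nc1n2[C@H]2OC[C@@H](O)[C@H]2OC1`, gives 2250 nM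

Compound 1 stands at the highest of the two numbers that this read-out gives. Its nearest neighbour is compound 3, which carries the same 4-(trifluoromethyl)phenyl amine on the other carbon of the quinone ring and gives a lower number, a gap that lies beyond the usual scatter of repeated measurements. For compound 2, with a pyrrolidine in place of the anilino group, the assay reports only a limit and no number, (the limit of > 16000 nM in this assay, at which 1 of the 3 values shown sits).

The step now followed leads from compound 1 to compound 4, `COc1ccccc1NC1=CC(=O)c2nc3n(c2C1=O)[C@H]1OC[C@@H](O)[C@H]1OC3`. The change is 2-methoxyphenyl in place of 4-(trifluoromethyl)phenyl on an amine nitrogen. Among the compounds with values here, no measured pair shows this exchange, so the size of the step can only be judged from the spread of the three values: the two anilino compounds sit within a narrow band while the pyrrolidine compound falls to a limit. The step is expected to be modest, a 1.3-fold higher number from compound 1 to compound 4 (0.10 log units; within the scatter), with no clear direction beyond the scatter. Compound 4 is therefore estimated at 7000 nM, within a range from 2500 nM to 16000 nM.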

Compound 4, half-maximal inhibitory concentration: > 4000 nM
Compound 4: a limit, no number (the forecaster's own chance of this, stated with the estimate: 25%); the middle value lies beyond the limit too.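

In this assay compound 4 gives > 4000 nM, which is a limit of the assay and not a number. Within the data shown here, no step from compound 1 to compound 4 can be read. The compounds shown leave open whether 2-methoxyphenyl in place of 4-(trifluoromethyl)phenyl on an amine nitrogen changes the read-out at all, and in which direction.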